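Ethyl to isopropyl on a shared core

This account rests on a few compounds, and the source may have more. Where it says the series, first, only, none or still open, it means among the compounds named here.

In an ADME assay on MT4 cells (Homo sapiens) for cytotoxicity, read by MTT assay, with a stated time of 4 days (on this read-out higher numbers stand for lower toxicity in this test and lower numbers for higher toxicity in this test), compound 1 (`CCCNc1nc(C(C)c2c(F)cccc2F)c(C)c(=O)[nH]1`) gives a measured number, 35000 nM on this scale. Compound 2 (`CN(C)c1nc(Cc2c(F)cccc2F)cc(=O)[nH]1`) gives only a limit, > 94000 nM as reported. Compound 3 (`CCN(C)c1nc(Cc2c(F)cccc2F)cc(=O)[nH]1`) also gives only a limit, > 89000 nM as reported, so it stands with compound 2 at a limit and has no exact number.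

Compound 4 (`CC(C)N(C)c1nc(Cc2c(F)cccc2F)cc(=O)[nH]1`) turns the ethyl of compound 3 into isopropyl (methyl in place of hydrogen on a saturated chain carbon bound to a nitrogen on an aromatic ring and a saturated chain carbon), so ethyl(methyl)amino becomes isopropyl(methyl)amino. The closest measured change is also methyl in place of hydrogen, but it offers no size to carry over (a step that the two limits leave unreadable from compound 2 to compound 3). For the measured compounds named here, the only measured number, from compound 1 (35000 nM), comes from a compound that differs in more than one place, so it only widens the lower side of the range. No step beyond the usual scatter is expected, and the estimated step (an at least 1.0-fold lower number from compound 3 to compound 4 (0.01 log units; that floor lies within the scatter)) is small. Compound 4 is expected near 85000 nM in this assay, with an estimated range from 40000 nM to 110000 nM and a good chance of another limit.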

Compound 4, half-maximal cytotoxic concentration: 85000 nM
Beside the measured number, compound 4's estimate shows no gap at the digits printed; low and high end bracket the measured number.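

In this assay, compound 4 gives an exact number, 85000 nM, so this position on the nitrogen now has a real value to compare against. Compound 2 and compound 3, by contrast, gave only limits. The change from ethyl to isopropyl is an at least 1.0-fold lower number from compound 3 to compound 4 (0.01 log units; that floor lies within the scatter), and isopropyl in place of methyl on the nitrogen is an at least 1.1-fold lower number from compound 2 to compound 4 (0.04 log units; that floor lies within the scatter), so neither change can be said to alter the read-out. Both steps remain floors, and the first cannot be sized further because compound 3 is held only at a limit of the assay: the limit of > 89000 nM in this assay, at which 1 of the 4 values shown sits.

The step from compound 2 to compound 3 cannot be read. The compounds shown leave open whether a longer chain, such as n-butyl, or a terminal amine on this nitrogen would give a step beyond the usual scatter.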